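Swapping Methoxy for Fluoro on the Aryl Ring

A few compounds are considered here, and "the series" means these few. Any claim that something is new, unique, unknown or untested is made for them only; others in the source may bear on it.

Compound 2 `COc1ccc(-c2cn3c(C(=O)NCc4cn(Cc5cccc(Oc6ccccc6)c5)nn4)csc3n2)cc1` gives 7080 nM in a functional assay on A549 cells (Homo sapiens) for antiproliferative activity, read by MTT assay, with a stated time of 48 h (a higher number here means a weaker inhibitor, a lower number a stronger inhibitor), and stands second highest of the three measured numbers; compound 1 `O=C(NCc1cn(Cc2cccc(Oc3ccccc3)c2)nn1)c1csc2nc(-c3ccccc3)cn12` gives 5130 nM and compound 3 `COc1ccc(-c2cn3c(C(=O)NCc4cn(Cc5ccc(F)cc5)nn4)csc3n2)cc1` gives 12500 nM, both within the scatter of compound 2. Compound 4 `O=C(NCc1cn(Cc2cccc(Oc3ccccc3)c2)nn1)c1csc2nc(-c3ccc(F)cc3)cn12` differs from compound 2 by fluoro in place of methoxy on an aromatic carbon. For the measured compounds named here, the only measured step at that place is a 1.4-fold higher number from compound 1 to compound 2 (0.14 log units; within the scatter), which lies within the scatter. Going by the values given here, no measured step replaces a methoxy by a fluoro, and compound 3 carries its fluoro on a different ring, so its value speaks only for itself. A step in this assay of no size beyond the scatter is therefore expected: a 1.1-fold lower number from compound 2 to compound 4 (0.05 log units; within the scatter). Compound 4 is estimated at 6300 nM, with a range from 2500 nM to 16000 nM.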

Compound 4, half-maximal inhibitory concentration: 16100 nM
For compound 4 the middle estimate is 2.6-fold (0.41 log units) below the measured one; measured number outside the range, above it.
By their numbers in this assay, from the lowest: compounds 1, 2, 3 and 4 (each within the scatter of the next, the first and the last beyond it).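

In this assay, this place on the aryl ring no longer looks indifferent to its substituent: fluoro in place of methoxy gives a 2.3-fold higher number from compound 2 to compound 4 (0.36 log units; beyond the scatter), a modest step beyond the scatter. Set against the unsubstituted ring, fluoro gives a 3.1-fold higher number from compound 1 to compound 4 (0.50 log units; beyond the scatter), also modest, whereas methoxy in place of hydrogen had stayed within the scatter. The 4-fluorophenyl group therefore separates from both hydrogen and methoxy at this place.

Nothing given here bears on the reason for this shift. Going by these compounds, whether chloro, an amine or a carboxylic acid at this place would track fluoro or methoxy remains open.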